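Moving the Hydroxyl Around the Ester Ring

The source may hold more compounds than are shown below. What is called first, only, known or untested is meant among the compounds shown, and "the series" means these compounds.

Compound 3 `COc1cc(C2CC(=NOC(=O)c3ccccc3O)CC(c3ccc(O)c(OC)c3)N2C)ccc1O` gives 15900 nM in a functional assay, read by spectrophotometry, with a stated time of 30 min (a lower number here means a stronger inhibitor, a higher number a weaker inhibitor), the lowest number among the three measured compounds; compound 2 `COc1ccc(C(=O)ON=C2CC(c3ccc(O)c(OC)c3)N(C)C(c3ccc(O)c(OC)c3)C2)c(OC)c1` gives 41000 nM and compound 1 `COc1cc(C2CC(=NOC(=O)c3ccc(Cl)cc3)CC(c3ccc(O)c(OC)c3)N2C)ccc1O` gives 112000 nM. Compound 4 `COc1cc(C2CC(=NOC(=O)c3ccc(O)cc3)CC(c3ccc(O)c(OC)c3)N2C)ccc1O` differs from compound 3 by 4-hydroxyphenyl in place of 2-hydroxyphenyl on a carbonyl carbon. Going by the values given here, two measured steps concern the same carbonyl carbon: a 7.0-fold lower number from compound 1 to compound 3 (0.85 log units; beyond the scatter) and a 2.6-fold lower number from compound 2 to compound 3 (0.41 log units; beyond the scatter), each a swap of the whole aromatic group at that position. Neither of them moves a hydroxyl from one place on the ring to another, so this exact change has not been measured. Compound 3 stands lowest and its nearest step, a 2.6-fold lower number from compound 2 to compound 3 (0.41 log units; beyond the scatter), is modest, so a step back toward the other two numbers seems plausible. Compound 4 is therefore expected to show a 1.6-fold higher number from compound 3 to compound 4 (0.20 log units; within the scatter). Compound 4 is estimated at 25000 nM, with a range from 8000 nM to 80000 nM.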

Compound 4, half-maximal inhibitory concentration: 15100 nM
Beside the measured number, compound 4's estimate is 1.7-fold (0.22 log units) above it; low and high end bracket the measured number.
By their numbers in this assay, from the lowest: compounds 4 and 3 (each within the scatter of the next); then compound 2; then compound 1.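

Moving the hydroxyl, 4-hydroxyphenyl in place of 2-hydroxyphenyl on the carbonyl carbon, gives two compounds that cannot be told apart in this assay (a 1.1-fold lower number from compound 3 to compound 4 (0.02 log units; within the scatter)), so the ring place of this hydroxyl makes no measurable difference here. Compound 4 also stands clear of the other two esters, both against 2,4-dimethoxyphenyl (a 2.7-fold lower number from compound 2 to compound 4 (0.43 log units; beyond the scatter)) and against the chloro compound (a 7.4-fold lower number from compound 1 to compound 4 (0.87 log units; beyond the scatter)). Nothing measured here accounts for these steps. From the compounds shown here alone, whether an amine or a carboxylic acid in place of the hydroxy on this ring would match compound 3 and compound 4 stays open.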